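Swapping the ring-bound acid for an open-chain one

The compounds below may be only part of what the source reports. "The series", "measured", "known", "first", "only" and "open" are said of these compounds alone.

Three compounds share a core and differ in the acid-bearing piece attached through an amide. Compound 1 `O=C(O)[C@@H]1CCCN1C(=O)CN(c1nc(Cl)nc2[nH]cnc12)C1CC1` carries a ring-closed acid; in a functional assay on the whole organism (Tail, strain ICR) with Mus musculus as the target, in the tail flick test, with a stated time of 90 min, at a dose of 25 umol/kg by the oral route (a higher number here means a stronger effect of the compound at the dose given, a lower number a weaker effect), compound 1 gives 26%. Compound 2 `O=C(CN(c1ncnc2c1ncn2C1CCCCO1)C1CC1)N[C@@H](CCC(=O)OCc1ccccc1)C(=O)OCc1ccccc1` gives 25.2%, within the scatter of compound 1. Compound 3 `O=C(OCc1ccccc1)[C@@H]1CCCN1C(=O)CN(c1nc(Cl)nc2[nH]cnc12)C1CC1` is the benzyl ester of compound 1; in this assay compound 3 gives 43.3%. For the measured compounds named here, compound 1 therefore stands second of the three numbers, and the only step measured in one place, a number 17.3 percentage points higher from compound 1 to compound 3 (beyond the scatter), concerns capping the acid, not exchanging the amino acid itself.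

Compound 4 `CC(C)[C@H](NC(=O)CN(c1nc(Cl)nc2[nH]cnc12)C1CC1)C(=O)O` keeps the free acid but opens the ring: (1-carboxy-2-methylpropyl)amino in place of 2-carboxypyrrolidin-1-yl on a carbonyl carbon. Going by the values given here, no measured pair shows what this exchange does; compound 2 differs from compound 1 in several places at once, so its value only shows that another amino-acid acid sits in the same region. With the acid kept free, compound 4 is expected to move little, giving an estimated step of a number 2 percentage points higher from compound 1 to compound 4 (within the scatter) in this assay. Compound 4 is thus estimated at 28%, with a likely range from 12% to 45%.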

Compound 4, a percentage reported as activity, at one dose (the size of the read-out at that dose, not a potency): 30.3%
Beside the measured number, compound 4's estimate is 2.3 percentage points below it; measured number inside the range.
By their numbers in this assay, from the lowest: compounds 2, 1 and 4 (each within the scatter of the next); then compound 3.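

For the compounds shown here, this is the first exchange of the acid-bearing piece that can be read in one place: with the free acid kept, opening the ring gives a number 4.3 percentage points higher from compound 1 to compound 4 (within the scatter) in this assay. At this position, then, the closed ring of 2-carboxypyrrolidin-1-yl is not required to keep the read-out at this dose, at least when (1-carboxy-2-methylpropyl)amino takes its place, whereas capping the acid gave a number 17.3 percentage points higher from compound 1 to compound 3 (beyond the scatter). Nothing available here explains why the ring exchange stays within the scatter while the benzyl ester does not.

From the compounds shown here alone, whether a benzyl ester on compound 4 would bring the same kind of step as on compound 1 remains open. So does the outcome for an open-chain acid with a longer chain, or with an amine at the end of that chain.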